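This account rests on a few compounds, and the source may have more. Where it says the series, first, only, none or still open, it means among the compounds named here.

Three compounds of the series have been run in a functional assay on MDA-MB-468 cells (Homo sapiens) for cytotoxicity, read by resazurin assay, with a stated time of 72 h; a lower number here means a stronger inhibitor, a higher number a weaker inhibitor. Compound 1 `CCCCOC(=O)CCSC(=S)NCc1cccnc1` carries an ester-terminated chain on the shared core; in this assay compound 1 gives 12800 nM. Compound 2 `CC1(C)OB(CCCSC(=S)NCc2cccnc2)OC1(C)C` carries a different chain on the same core; in this assay compound 2 gives 6620 nM. Compound 3 `Fc1ccccc1-c1nnc(CCSC(=S)NCc2cccnc2)o1` carries a 2-fluorophenyl group on a five-membered aromatic ring with 2 nitrogen and 1 oxygen; in this assay compound 3 gives 3420 nM.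

Compound 3 stands at the lowest of the three numbers. Compound 2 lies within the scatter of compound 3, so no order between the two is claimed. Compound 1 lies beyond the scatter of compound 3, so compound 3 is the clearly lower of that pair only.

Compound 4 `S=C(NCc1cccnc1)SCCc1nnc(-c2cccnc2)o1` has not been measured. It differs from compound 3 in one place: pyridin-3-yl in place of 2-fluorophenyl on an aromatic carbon. Among the compounds with values here, no pair of measured compounds covers a change of this kind, so the expectation rests on compound 3 alone. The step in this assay is expected to be a 1.3-fold higher number from compound 3 to compound 4 (0.12 log units; within the scatter), that is no change beyond the scatter, leaning if anything to a somewhat higher number. Compound 4 is expected to give 4500 nM in this assay, with a range from 1500 nM to 14000 nM.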

Compound 4, half-maximal inhibitory concentration: 3160 nM
For compound 4 the middle estimate is 1.4-fold (0.15 log units) above the measured one; measured number inside the range.
By their numbers in this assay, from the lowest: compounds 4, 3, 2 and 1 (each within the scatter of the next, the first and the last beyond it).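

In this assay, pyridin-3-yl in place of 2-fluorophenyl on the aromatic carbon of the five-membered aromatic ring with 2 nitrogen and 1 oxygen gives a 1.1-fold lower number from compound 3 to compound 4 (0.03 log units; within the scatter), so no difference between the two groups can be read at this position. Within the data shown here, this is the first step measured here: until now the position was known only through compound 3, and it now holds two different six-membered aromatic rings with values within the scatter of each other, one of carbon only and one with 1 hetero atom, the first group with 0 hydrogen-bond acceptors and the second with 1. Nothing at hand explains why this exchange leaves the number in place, as no supporting data bear on the result.

As far as these compounds go, both groups tried here are six-membered aromatic rings, so it remains open whether the same aromatic carbon would give a similar number with an amine, a carboxylic acid or a short alkyl chain in their place. Also open, from the compounds shown here alone, is whether a longer chain between the sulfur and the five-membered ring would alter the number for compound 4.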